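Swapping a ring amine for a dimethylamino group

This account rests on a few compounds, and the source may have more. Where it says the series, first, only, none or still open, it means among the compounds named here.

Of the compounds shown here, three have been measured in a functional assay on HCT-116 cells (Homo sapiens) for antiproliferative activity, read by sulforhodamine B assay, with a stated time of 72 h; on this read-out higher numbers stand for weaker inhibition and lower numbers for stronger inhibition. Compound 1 `O=C(N[C@@H]1CNCC[C@H]1c1ccc(Cl)cc1)c1ccc(-c2ncnc3c2CCC3O)s1` gives 23000 nM. Compound 2 `Cn1ncc(Cl)c1-c1cc(C(=O)N[C@@H]2CN[C@H](CCN3CCCC3)C[C@H]2c2ccc(Cl)c(Cl)c2)oc1Cl` gives 1940 nM, and compound 3 `Cn1ncc(Cl)c1-c1cc(C(=O)N[C@@H]2CN[C@H](CC(O)CO)C[C@H]2c2ccc(F)c(F)c2)oc1Cl` gives 800 nM. Among these three numbers compound 2 stands second highest: compound 3 lies lower by an amount beyond the usual scatter, while compound 1 lies higher, also beyond the scatter. Compound 2 is therefore neither the strongest nor the weakest inhibitor of the set.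

Compound 4 `CN(C)CC[C@@H]1C[C@@H](c2ccc(Cl)c(Cl)c2)[C@H](NC(=O)c2cc(-c3c(Cl)cnn3C)c(Cl)o2)CN1` has not yet been measured in this assay. It differs from compound 2 in one place only: dimethylamino in place of pyrrolidin-1-yl on a saturated chain carbon, two bonds along the chain from a saturated ring carbon. The change sits on a saturated chain carbon, two bonds along the chain from a saturated ring carbon, and both the leaving and the entering group carry one hydrogen-bond acceptor and no charge. For the measured compounds named here, with no measured pair showing this exact change, the step is expected to be small, with a 1.1-fold higher number from compound 2 to compound 4 (0.05 log units; within the scatter) likely within the scatter and leaning, if anywhere, toward a slightly higher number. Compound 4 is accordingly estimated at 2200 nM, with a plausible range from 900 nM to 5500 nM.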

Compound 4, half-maximal inhibitory concentration: 1710 nM
Compound 4: the middle estimate sits 1.3-fold (0.11 log units) above what was measured; the measured number falls inside the stated range.
By their numbers in this assay, from the lowest: compound 3; then compounds 4 and 2 (each within the scatter of the next); then compound 1.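

In this assay, dimethylamino in place of pyrrolidin-1-yl on a saturated chain carbon, two bonds along the chain from a saturated ring carbon, gives a 1.1-fold lower number from compound 2 to compound 4 (0.05 log units; within the scatter). For the compounds shown here, this is the first pair in the set that differs in one place only, and it shows that at this position, the ring of pyrrolidin-1-yl can give way to a smaller group with no ring without a difference this assay can tell apart from scatter. No measurement at hand explains why the two groups read alike.

The compounds shown leave open how a primary amine, a carboxylic acid or a longer chain would read at this place. They also leave open whether dimethylamino and pyrrolidin-1-yl would still read alike on a different core.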